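Replacing a benzyl arm with a thiourea arm on the shared core

The source may report more compounds than this note shows. Statements on the series, on what has been measured and on what is new or still open speak of the compounds shown alone.

Compound 1 `NC(=O)c1c(NC(=O)c2ccccc2Cl)sc2c1CCN(Cc1ccccc1Cl)C2` — 2900 nM
Compound 2 `NC(=O)c1c(NC(=O)c2ccc(C(F)(F)F)cc2)sc2c1CCN(Cc1ccc(Cl)cc1Cl)C2` — 14900 nM
Compound 3 `NC(=O)c1c(NC(=O)c2cccc([N+](=O)[O-])c2)sc2c1CCN(Cc1c(Cl)cccc1Cl)C2` — 18400 nM

Of the compounds shown here, three of the shared core have been measured in a functional assay on HL-60 cells (Homo sapiens) for antiproliferative activity, with a stated time of 24 h; a lower number here means a stronger inhibitor, a higher number a weaker inhibitor. Compound 1 gives the lowest number of the three; compound 2 and compound 3 both sit higher, and each of those two gaps lies beyond the usual scatter, so compound 1 is the strongest inhibitor of this set. Among the measured compounds shown here, no pair of these three differs in only one place, so none of their gaps can be read as a single step.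

Compound 4 `NC(=O)c1c(NC(=O)c2ccccc2Cl)sc2c1CCN(C(=S)Nc1ccccc1Br)C2` has not yet been measured. It differs from compound 1 in one place: a group of 10 heavy atoms (7 carbon, 1 nitrogen, 1 sulfur, 1 bromine; one six-membered aromatic ring of carbon only) in place of a group of 8 heavy atoms (7 carbon, 1 chlorine; one six-membered aromatic ring of carbon only), on an amine nitrogen in a ring. For the measured compounds named here, the set gives no earlier example of an exchange of this kind on the amine nitrogen in a ring, so there is no measured step to lean on. The expected step of a 1.6-fold higher number from compound 1 to compound 4 (0.19 log units; within the scatter) is therefore small and toward a weaker inhibitor, with a wide range. Compound 4 is estimated at 4500 nM, within 1200 nM to 17000 nM.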

Compound 4, half-maximal inhibitory concentration: 9090 nM
Beside the measured number, compound 4's estimate is 2.0-fold (0.31 log units) below it; the measured number falls inside the stated range.
By their numbers in this assay, from the lowest: compound 1; then compounds 4, 2 and 3 (each within the scatter of the next, the first and the last beyond it).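

Among the compounds shown here, compound 4 gives the first single-change reading at the amine nitrogen in a ring of the shared core. In this assay, exchanging the 2-chlorobenzyl arm for the thiourea arm gives a modest loss of strength (a 3.1-fold higher number from compound 1 to compound 4 (0.50 log units; beyond the scatter)), so this position accepts an arm carrying one hydrogen-bond donor and one hydrogen-bond acceptor, which the 2-chlorobenzyl arm lacks, at a measurable but limited cost. No measurement here accounts for the rise in the number.

The exchange alters the link to the aromatic ring and swaps chlorine for bromine in one step, so the compounds shown cannot separate the two contributions. Also open, from the compounds shown here alone, is how this nitrogen would behave with a urea, with oxygen in place of sulfur, or with an acetyl group or a free amine.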